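The compounds below may be only part of what the source reports. "The series", "measured", "known", "first", "only" and "open" are said of these compounds alone.

Measured compounds in a functional assay on CHO cells for agonist activity at adenosine receptor A1 (Homo sapiens), read by fluorescence and ERK phosphorylation, with stated times of 30 min and 1.5 h, tested at 3 uM; on this read-out lower numbers stand for a weaker effect and higher numbers for a stronger effect at the one concentration tested:
- compound 1, `Nc1scc(-c2cccc(C(F)(F)F)c2)c1C(=O)c1ccccc1`, gives 83%
- compound 2, `Nc1scc(-c2ccccc2)c1C(=O)c1ccccc1`, gives 49%
- compound 3, `Nc1scc(-c2ccc(Cl)cc2)c1C(=O)c1ccccc1`, gives 46%

All three share a core, and they differ only in the group that sits on one ring carbon. Compound 3 carries a 4-chlorophenyl there. Its number cannot be told apart from that of compound 2, because a number 3 percentage points lower from compound 2 to compound 3 (within the scatter). Compound 1, with a trifluoromethyl on its phenyl, stands clearly above both.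

Compound 4, `Nc1scc(-c2cccc(Br)c2)c1C(=O)c1ccccc1`, has not yet been measured. The change from compound 3 is 3-bromophenyl in place of 4-chlorophenyl on an aromatic carbon.

Among the compounds with values here, two measured steps bear on this. The step of a number 34 percentage points lower from compound 1 to compound 2 (beyond the scatter) shows that a substituent on the phenyl can matter a great deal. The step of a number 3 percentage points lower from compound 2 to compound 3 (within the scatter) shows that a chloro added in another spot did not. A bromo, like the trifluoromethyl of compound 1, sits in the 3-position of the phenyl, so the step from compound 3 to compound 4 is expected to be upward, roughly a number 19 percentage points higher from compound 3 to compound 4 (beyond the scatter).

Compound 4 is therefore estimated at 65%, with a range from 42% to 88%.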

Compound 4, a percentage reported as activity, at one concentration (the size of the read-out at that concentration, not a potency): 67%
The estimate for compound 4 lay 2 percentage points below the measured number, and the stated range covers the measured number.
By their numbers in this assay, from the lowest: compounds 3 and 2 (each within the scatter of the next); then compound 4; then compound 1.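

In this assay, the 3-bromophenyl group stands clearly above the 4-chlorophenyl group, a number 21 percentage points higher from compound 3 to compound 4 (beyond the scatter), and a bromo also counts when set against plain hydrogen, a number 18 percentage points higher from compound 2 to compound 4 (beyond the scatter), so a halogen on this phenyl can raise the number, which the chloro step alone did not show. The trifluoromethyl group still stands higher than the bromo, a number 16 percentage points lower from compound 1 to compound 4 (beyond the scatter), so the identity of the group matters as well as its presence. No measurement here explains these differences.

The step to compound 4 changes both the halogen and its place on the phenyl, so the compounds shown do not separate these two changes. On these data alone, how a methoxy group or an amine on the phenyl would compare also remains open.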